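A few compounds are considered here, and "the series" means these few. Any claim that something is new, unique, unknown or untested is made for them only; others in the source may bear on it.

In a functional assay, read by fluorescence and spectrophotometry, with a stated time of 1 h (on this read-out lower numbers stand for an effect already at smaller amounts and higher numbers for an effect only at larger amounts of compound), compound 1 (`O=S(=O)(/C=C/c1ccc(O)c(O)c1)CC1CC1`) gives 10500 nM and compound 2 (`CCCCCS(=O)(=O)/C=C/c1ccc(O)c(O)c1`) gives 8100 nM while compound 3 (`O=S(=O)(/C=C/c1ccc(O)c(O)c1)CCC1CCCC1`) gives 6800 nM and so stands level with both within the scatter. Compound 4 (`O=S(=O)(/C=C/c1ccc(O)c(O)c1)CCCc1ccccc1`) is still to be measured and differs from compound 3 in one group (benzyl in place of cyclopentyl on a saturated chain carbon, two bonds along the chain from a sulfonyl sulfur): benzyl in place of cyclopentyl on a saturated chain carbon, two bonds along the chain from a sulfonyl sulfur. At that same place, the step of a 1.2-fold lower number from compound 2 to compound 3 (0.08 log units; within the scatter) came with cyclopentyl in place of propyl. Two other changes to the saturated group gave small steps as well (a 1.3-fold lower number from compound 1 to compound 2 (0.11 log units; within the scatter)) and (a 1.5-fold lower number from compound 1 to compound 3 (0.19 log units; within the scatter)). For the measured compounds named here, none of these steps goes beyond the scatter, but no measured compound carries an aromatic ring at this place. The expected step in this assay is a 1.4-fold lower number from compound 3 to compound 4 (0.13 log units; within the scatter) and it is not expected to leave the scatter. Compound 4 is estimated at 5000 nM with an expected range of 2000 nM to 11000 nM around that value.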

Compound 4, half-maximal effective concentration: 11500 nM
Compound 4: middle estimate off by 2.3-fold (0.36 log units), on the low side, outside the stated range (above it).
By their numbers in this assay, from the lowest: compounds 3, 2, 1 and 4 (each within the scatter of the next).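

In this assay, benzyl in place of cyclopentyl brings the only aromatic ring at this place among these compounds and comes with a 1.7-fold higher number from compound 3 to compound 4 (0.23 log units; within the scatter), while phenyl in place of ethyl, on the chain carbon three bonds along from the sulfonyl sulfur, comes with a 1.4-fold higher number from compound 2 to compound 4 (0.15 log units; within the scatter). Neither step leaves the scatter, so an aromatic ring at the end of the chain reads the same here as the saturated groups, and this position has still shown no clear response to a change of group. Nothing available explains the values or bears on this result.

On these data alone, every group at this place contains only carbon, so it remains open whether an amine, a carboxylic acid or a much longer chain would give a step beyond the scatter. As far as these compounds go, all four compounds also share the same core, so the effect of changing that core remains open too.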